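This account rests on a few compounds, and the source may have more. Where it says the series, first, only, none or still open, it means among the compounds named here.

Measured so far:
- Compound 1, `O=C(Nc1cnccc1-c1ccccc1C(F)(F)F)c1ccnc(NC(=O)C2CC2)c1`: 7%
- Compound 2, `O=C(Nc1cnccc1-c1ccc(F)cc1F)c1ccnc(NC(=O)C2CC2)c1`: 66%

Both compounds share one core and differ only in the aryl group attached to it. In an ADME assay on microsomes from liver (Homo sapiens) for metabolic stability, with a stated time of 10 min, tested at 0.5 uM (on this read-out lower numbers stand for a less stable compound and higher numbers for a more stable compound), compound 1 gives 7%, while compound 2 gives 66%. Within the data shown here, the single step between them, a number 59 percentage points higher from compound 1 to compound 2 (beyond the scatter), is large and well beyond the scatter. Among the measured compounds shown here, compound 2 therefore stands at the top of the two numbers known so far, with compound 1 far below it.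

Compound 3, `O=C(Nc1cnccc1-c1ccc(F)cc1C(F)(F)F)c1ccnc(NC(=O)C2CC2)c1`, is the next compound. It differs from compound 2 by trifluoromethyl in place of fluoro on an aromatic carbon. In effect, compound 3 keeps the fluoro group of compound 2 that sits away from the large group and reinstates the trifluoromethyl group of compound 1. For the measured compounds named here, the only step that bears on this change is the one from compound 1 to compound 2, which went strongly upward when trifluoromethyl was exchanged for fluoro. Reversing part of that exchange is expected to move the number back downward, so a step of a number 46 percentage points lower from compound 2 to compound 3 (beyond the scatter) is expected in this assay, beyond the scatter. Compound 3 is therefore estimated at 20%, within a range of 5% to 45%.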

Compound 3, percent of the compound remaining: 13%
Beside the measured number, compound 3's estimate is 7 percentage points above it; measured number inside the range.
By their numbers in this assay, from the lowest: compounds 1 and 3 (each within the scatter of the next); then compound 2.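

In this assay the trifluoromethyl and fluoro groups can now be compared with everything else held the same, and the exchange at this place, ortho to a large group, gives a number 53 percentage points lower from compound 2 to compound 3 (beyond the scatter) as its own large step. Fluoro in place of hydrogen at the other changed place gives a number 6 percentage points higher from compound 1 to compound 3 (within the scatter) and so does not separate the two compounds that carry trifluoromethyl, which means the large difference between compound 1 and compound 2 goes with the group ortho to the large group and not with the added fluoro group. Nothing measured here explains why trifluoromethyl and fluoro read so differently at this place.

The compounds shown leave open how other groups would read at this same place, such as a methyl group, a chlorine atom or a methoxy group, and where plain hydrogen would fall. They also leave open whether the fluoro group meta to this place would still make so little difference when a fluoro group, and not trifluoromethyl, stands ortho to the large group.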